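This account rests on a few compounds, and the source may have more. Where it says the series, first, only, none or still open, it means among the compounds named here.

Compound 1 `O=C1NC[C@@H](c2c[nH]c3cc(Br)ccc23)N=C1c1c[nH]c2ccccc12`: 4.2 ug/mL
Compound 2 `O=C1NC[C@@H](c2c[nH]c3ccccc23)N=C1c1c[nH]c2ccccc12`: 4.79 ug/mL
Compound 3 `O=C1NC[C@@H](c2c[nH]c3ccccc23)N[C@H]1c1c[nH]c2ccccc12`: > 10 ug/mL

All three were run in an ADME assay on HCT-15 cells (Homo sapiens) for cytotoxicity; a lower number here means that less compound is needed, a higher number that more compound is needed for the effect. Compound 2 gives 4.79 ug/mL and compound 1 gives 4.2 ug/mL, so the step of a 1.1-fold lower number from compound 2 to compound 1 (0.06 log units; within the scatter) comes from bromo in place of hydrogen on an aromatic carbon. For compound 3 the assay returns only (the limit of > 10 ug/mL in this assay, at which 1 of the 3 values shown sits), a limit and not a number. How the core of compound 3 differs from that of compound 2 is not broken down here.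

Compound 4 `O=C1NC[C@@H](c2c[nH]c3ccccc23)N[C@H]1c1c[nH]c2cc(Br)ccc12` has not yet been measured in this assay. It differs from compound 3 by bromo in place of hydrogen on an aromatic carbon, the same change already seen from compound 2 to compound 1. The step from compound 3 to compound 4 in this assay is expected to be small, a step that the limit leaves unreadable from compound 3 to compound 4, resting on the step of a 1.1-fold lower number from compound 2 to compound 1 (0.06 log units; within the scatter). Compound 4 is therefore estimated at about 12 ug/mL, most likely between 5 ug/mL and 30 ug/mL, and it is expected that this assay may again report only a limit for compound 4.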

Compound 4, concentration for half-maximal effect: > 10 ug/mL
Compound 4: a limit, no number; the forecaster's own chance of this, stated with the estimate: 60%; the middle value does not contradict the limit.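

In this assay compound 4 gives > 10 ug/mL, which is a limit and not a number. Compound 3 sits at the same limit, so no step can be read between compound 3 and compound 4: the limit of > 10 ug/mL in this assay, at which 2 of the 4 values shown sit.

On these data alone, whether bromo in place of hydrogen shifts this read-out on the core of compound 3 stays open.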